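A few compounds are considered here, and "the series" means these few. Any claim that something is new, unique, unknown or untested is made for them only; others in the source may bear on it.

Among the compounds with values here, compound 1 `OC[C@H]1OC(n2cnc3c(-c4ccc(Cl)cc4)ncnc32)[C@H](O)[C@@H]1O` gives 900 nM in a functional assay on CCRF-CEM cells (Homo sapiens) for inhibition (on this read-out lower numbers stand for stronger inhibition and higher numbers for weaker inhibition), and holds the only numerical reading in this small set. Compound 2 `Cn1nccc1-c1ncnc2c1ncn2C1O[C@H](CO)[C@@H](O)[C@H]1O` is reported as "not active" (no number reported) in this assay without a number. Within the data shown here, compound 3 `OC[C@H]1OC(n2cnc3c(-c4ccc(O)cc4)ncnc32)[C@H](O)[C@@H]1O` differs from compound 1 by hydroxy in place of chloro on an aromatic carbon, with no measured pair showing the same change. The step from compound 1 to compound 3 is expected to be a 2.2-fold higher number from compound 1 to compound 3 (0.35 log units; beyond the scatter), a modest weakening that may barely exceed the usual scatter. Compound 3 is accordingly estimated at 2000 nM, with a plausible range from 500 nM to 8000 nM.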

Compound 3, half-maximal inhibitory concentration: 1250 nM
The estimate for compound 3 lay 1.6-fold (0.20 log units) above the measured number; measured number inside the range.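

In this assay, hydroxy in place of chloro on an aromatic carbon, para to a large group, gives a 1.4-fold higher number from compound 1 to compound 3 (0.14 log units; within the scatter). At this position, the two groups therefore cannot be told apart on this read-out, and the added hydrogen-bond donor and acceptor bring no change beyond the scatter. No measured evidence bears on why this is so. As far as these compounds go, whether an amine, a methoxy group or a carboxylic acid on the same carbon would also stay this close to compound 1 remains open. Within the data shown here, compound 2 carries no number, so no step to it can be read.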